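The source may report more compounds than this note shows. Statements on the series, on what has been measured and on what is new or still open speak of the compounds shown alone.

Measured compounds:
Compound 1, `C[C@H]1[C@H](NC(=O)OCCCCC2CCCCC2)C(=O)N1OCCCS(C)(=O)=O`, gives 49 nM in an assay on HEK293 cells for inhibition of N-acylethanolamine-hydrolyzing acid amidase (Homo sapiens), read by fluorescence, with stated times of 10 min and 50 min; a higher number here means a weaker inhibitor, a lower number a stronger inhibitor.
Compound 2, `C[C@H]1[C@H](NC(=O)OCCCCC2CCCCC2)C(=O)N1Oc1ccccc1`, gives 23 nM in this assay.

Both compounds share the same core and differ only in the group carried on the ring oxygen. Going by the values given here, the one measured step, a 2.1-fold lower number from compound 1 to compound 2 (0.33 log units; beyond the scatter), exchanges 3-(methylsulfonyl)propyl for phenyl on that oxygen. Among the compounds with values here, compound 2 therefore stands at the lower of the two numbers, and compound 1 is its only neighbour, separated from it by a modest step that lies beyond the scatter.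

Compound 3, `C[C@H]1[C@H](NC(=O)OCCCCC2CCCCC2)C(=O)N1Oc1ccc(C(F)(F)F)cc1`, has not yet been measured. It differs from compound 2 by trifluoromethyl in place of hydrogen on an aromatic carbon. Within the data shown here, no measured step bears directly on this change: the single step from compound 1 to compound 2 swaps the whole group on the oxygen rather than adding a substituent to a phenyl already present, so it gives no guide to the size or direction of the new step. The expectation therefore rests on compound 2 alone, and the step expected from compound 2 to compound 3 is a 1.0-fold lower number from compound 2 to compound 3 (0.02 log units; within the scatter), that is, none beyond the scatter. Compound 3 is estimated at 22 nM, with a range from 8 nM to 60 nM.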

Compound 3, half-maximal inhibitory concentration: 31 nM
The estimate for compound 3 lay 1.4-fold (0.15 log units) below the measured number; the range from low to high includes it.
By their numbers in this assay, from the lowest: compounds 2, 3 and 1 (each within the scatter of the next, the first and the last beyond it).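

At this position, on an aromatic carbon para to a large group, trifluoromethyl can replace hydrogen with a 1.3-fold higher number from compound 2 to compound 3 (0.13 log units; within the scatter) in this assay, so the added four heavy atoms produce no step beyond the scatter. The exchange on the oxygen also reads differently with this new group: phenyl in that place had given a step beyond the scatter from 3-(methylsulfonyl)propyl, whereas 4-(trifluoromethyl)phenyl gives a 1.6-fold lower number from compound 1 to compound 3 (0.20 log units; within the scatter), which leaves compound 3 within the scatter of both other compounds. Nothing at hand accounts for these numbers.

The three compounds do not show whether this tolerance extends to other groups at the same place, such as an amine, a carboxylic acid or a nitrile, or whether a single chlorine atom would fall within the scatter of compound 2 as well. They also leave open what trifluoromethyl would do on another carbon of the aromatic ring, and whether a longer chain on the oxygen, or one ending in a group other than methylsulfonyl, would move the number beyond the scatter of compound 1.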